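The source may hold more compounds than are shown below. What is called first, only, known or untested is meant among the compounds shown, and "the series" means these compounds.

Compound 1 `Nc1ccccc1NC(=O)c1ccc(NC(=S)NCc2cccc(Cl)c2)cc1`: 2600 nM
Compound 2 `Nc1ccccc1NC(=O)c1ccc(NC(=O)NCc2cccnc2)cc1`: 5100 nM
Compound 3 `Nc1ccccc1NC(=O)c1ccc(NC(=S)NCc2cncc(Br)c2)cc1`: 7500 nM

In a functional assay on HepG2 cells (Homo sapiens) for cytotoxicity, read by MTT assay, with a stated time of 72 h (a higher number here means a weaker inhibitor, a lower number a stronger inhibitor), compound 2 gives 5100 nM, which lies within the usual scatter of the values for both compound 1 and compound 3. Compound 4 `Nc1ccccc1NC(=O)c1ccc(NC(=O)NCc2ccc(F)nc2)cc1` carries fluoro in place of hydrogen on an aromatic carbon, next to the ring nitrogen: fluoro in place of hydrogen on an aromatic carbon. Among the compounds with values here, the only measured step, a 2.9-fold higher number from compound 1 to compound 3 (0.46 log units; beyond the scatter), is modest and swaps a whole aryl group, so it offers just a rough sense of scale. Within the data shown here, no measured step shows what adding fluoro does. A change beyond the scatter is therefore not expected, and the expected step is a 1.1-fold lower number from compound 2 to compound 4 (0.05 log units; within the scatter). Compound 4 is estimated at 4500 nM, with an expected range from 1800 nM to 11000 nM.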

Compound 4, half-maximal inhibitory concentration: 13000 nM
The estimate for compound 4 lay 2.9-fold (0.46 log units) below the measured number, outside the stated range (above it).
By their numbers in this assay, from the lowest: compounds 1, 2, 3 and 4 (each within the scatter of the next, the first and the last beyond it).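

Replacing pyridin-3-yl with 6-fluoropyridin-3-yl gives a 2.5-fold higher number from compound 2 to compound 4 (0.41 log units; beyond the scatter) in this assay and so a weaker inhibitor. Unlike the earlier step, which swaps a whole aryl group, this one changes a single atom, so even one fluorine on this aromatic carbon is enough to move the result beyond the scatter. No measurement given here offers a reason for this loss. The compounds shown leave open whether a chloro, a methyl or an amino group on this same carbon would act like fluoro. They also leave open whether fluoro on another carbon of this ring would do the same.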